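The compounds below may be only part of what the source reports. "The series", "measured", "known", "first", "only" and "open" are said of these compounds alone.

Measured in a functional assay on HL-60 cells (Homo sapiens) for inhibition; on this read-out lower numbers stand for stronger inhibition of growth and higher numbers for weaker inhibition of growth:
- compound 1 `NS(=O)(=O)c1ccc(/C=C/c2ccc(O)c(O)c2)cc1`: 16300 nM
- compound 2 `NS(=O)(=O)c1ccc(/C=C/c2ccc(F)cc2)cc1`: 37300 nM
- compound 3 `NS(=O)(=O)c1ccc(/C=C/c2ccc(O)cc2)cc1`: 4350 nM

Of these three, compound 3 has the lowest number and so shows the strongest inhibition of growth, clearly ahead of both others. The next candidate is compound 4 `CN(C)c1ccc(/C=C/c2ccc(S(N)(=O)=O)cc2)cc1`, still unmeasured in this assay. It is made from compound 3 by one change, dimethylamino in place of hydroxy on an aromatic carbon.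

Two measured steps offer guidance, though neither involves dimethylamino. The closer one swaps the group at the same place, fluoro for hydroxy, and gives an 8.6-fold lower number from compound 2 to compound 3 (0.93 log units; beyond the scatter). Compound 3 therefore did better with hydroxy than compound 2 did with fluoro. The other step, a 3.7-fold lower number from compound 1 to compound 3 (0.57 log units; beyond the scatter), shows that adding a second hydroxy to the ring, as in compound 1, did not help. Both steps are modest, and compound 3 sits at the low end of this small set, so replacing its hydroxy is expected to raise the number somewhat.

The estimated step is a 2.1-fold higher number from compound 3 to compound 4 (0.32 log units; beyond the scatter). Going by the values given here, with no dimethylamino example measured, the uncertainty is wide. For compound 4 the estimated value is 9000 nM, with an expected range from 2000 nM to 35000 nM.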

Compound 4, concentration for 50% growth inhibition: > 100000 nM
Compound 4: a limit, no number (the forecaster's own chance of this, stated with the estimate: 5%); middle value at least 11-fold (1.04 log units) from the limit.
By their numbers in this assay, from the lowest: compound 3; then compound 1; then compound 2. At a limit, above all of these: compound 4.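

In this assay compound 4 gives > 100000 nM, which is a limit of the assay and not a number. Even read as a limit, the change to dimethylamino on this aromatic carbon, para to a large group, gives an at least 22-fold higher number from compound 3 to compound 4 (1.36 log units; beyond the scatter), the only step in this small set printed as large, so this position can respond far more sharply than the modest earlier steps suggested. Dimethylamino also falls behind fluoro at the same place, with an at least 2.6-fold higher number from compound 2 to compound 4 (0.42 log units; beyond the scatter), so the order of groups here runs from hydroxy through fluoro to dimethylamino, with growth inhibition weakening at each stage.

The compounds shown leave open how a plain amino group or a methoxy group at this place would compare with hydroxy, and so whether the loss goes with the carbons of dimethylamino or with giving up the hydrogen-bond donor that hydroxy carries. Also open, on these data alone, is whether a carboxylic acid here would stand nearer to hydroxy or to dimethylamino in this assay.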